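This account rests on a few compounds, and the source may have more. Where it says the series, first, only, none or still open, it means among the compounds named here.

Compound 1 `C/C(=N\NC(=O)c1ccc(C(F)(F)F)cc1)c1cnccn1`: 1160 nM
Compound 2 `O=C(NN=C(c1ccccn1)c1ccccn1)c1cccc(Br)c1`: 240 nM
Compound 3 `O=C(NN=C(c1ccccn1)c1ccccn1)c1ccc(O)cc1`: 7530 nM

All three were tested in an ADME assay on cells (Homo sapiens) for antiproliferative activity, read by MTT assay; on this read-out lower numbers stand for stronger inhibition and higher numbers for weaker inhibition. Compound 1 stands in the middle: compound 2 gives a lower number and compound 3 a higher one, both gaps beyond the scatter. Compound 4 `C/C(=N\NC(=O)c1ccc(N)cc1)c1cnccn1` differs from compound 1 in one place: amino in place of trifluoromethyl on an aromatic carbon. Among the compounds with values here, one measured step bears on this: a 31-fold higher number from compound 2 to compound 3 (1.50 log units; beyond the scatter), where 4-hydroxyphenyl replaced 3-bromophenyl and the number rose sharply. The change to compound 4 likewise replaces a fluorine-bearing group with a hydrogen-bond-donating amino, so a weakening beyond the scatter is expected, though the cores differ and the size is uncertain. Compound 4 is therefore estimated at 6000 nM (range 1500 nM to 25000 nM), an expected step of a 5.2-fold higher number from compound 1 to compound 4 (0.71 log units; beyond the scatter).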

Compound 4, half-maximal inhibitory concentration: 58800 nM
For compound 4 the middle estimate is 9.8-fold (0.99 log units) below the measured one; measured number above the stated range.
By their numbers in this assay, from the lowest: compound 2; then compound 1; then compound 3; then compound 4.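

In this assay, the aromatic carbon para to a large group proves highly sensitive to what it carries: amino in place of trifluoromethyl gives a 51-fold higher number from compound 1 to compound 4 (1.70 log units; beyond the scatter) on an otherwise unchanged structure. Within the data shown here, the earlier step, a 31-fold higher number from compound 2 to compound 3 (1.50 log units; beyond the scatter), came from a different core, so this is the first sign of such sensitivity on the core of compound 1. Nothing available gives a reason for this rise. From the compounds shown here alone, it remains open whether the gain of amino or the loss of trifluoromethyl matters more. A methyl group or a chlorine atom at this place could help separate the two.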